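Hydrazone aryl swap on a shared pyrimidine-dione core

A few compounds are considered here, and "the series" means these few. Any claim that something is new, unique, unknown or untested is made for them only; others in the source may bear on it.

Two members of the series have been measured in a functional assay on PC-3 cells (Homo sapiens) for antiproliferative activity, read by MTT assay; a lower number here means a stronger inhibitor, a higher number a weaker inhibitor. Compound 1 `Cn1c(=O)c(=O)n(C2CCCC2)c2nc(N/N=C/c3ccc(O)c(F)c3)ncc21` gives 85200 nM in this assay, and compound 2 `Cn1c(=O)c(=O)n(C2CCCC2)c2nc(N/N=C/c3cccs3)ncc21` gives 75600 nM. The step of a 1.1-fold lower number from compound 1 to compound 2 (0.05 log units; within the scatter) is the only one measured, and it puts compound 2 and compound 1 within the scatter of each other, so neither can be set apart from the other on these numbers. Compound 3 `Cn1c(=O)c(=O)n(C2CCCC2)c2nc(N/N=C/c3ccccc3F)ncc21` is not yet measured. Relative to compound 2 the change is 2-fluorophenyl in place of thiophen-2-yl on a carbon with a double bond to nitrogen. Among the measured compounds shown here, the single step that bears on this change is a 1.1-fold lower number from compound 1 to compound 2 (0.05 log units; within the scatter), where one aryl group on the same carbon was exchanged for another with no movement beyond the scatter. On that basis no step beyond the scatter is expected for the change from compound 2 to compound 3, and the estimated step is a 1.1-fold higher number from compound 2 to compound 3 (0.02 log units; within the scatter). Compound 3 is therefore expected to give about 80000 nM in this assay, within a range of 40000 nM to 160000 nM.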

Compound 3, half-maximal inhibitory concentration: 27600 nM
Beside the measured number, compound 3's estimate is 2.9-fold (0.46 log units) above it; the measured number lies below the stated range.
By their numbers in this assay, from the lowest: compound 3; then compounds 2 and 1 (each within the scatter of the next).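

Among the compounds shown here, the aryl group on the carbon with a double bond to nitrogen is not a silent position in this assay: the one earlier exchange there stayed within the scatter, but 2-fluorophenyl gives a 2.7-fold lower number from compound 2 to compound 3 (0.44 log units; beyond the scatter) and a 3.1-fold lower number from compound 1 to compound 3 (0.49 log units; beyond the scatter), both modest yet beyond the scatter, and compound 3 at 27600 nM now holds the lowest number of the three. A fluorine on a phenyl ring is not enough on its own to account for this, as compound 1 carries one in its 3-fluoro-4-hydroxyphenyl group and stays within the scatter of compound 2. No measurement at hand speaks to the reason for the movement at this position.

Among the compounds shown, the 2-fluorophenyl group differs from the other two groups in more than one feature, so the fluorine and the plain six-membered carbon ring cannot be told apart as the source of the step. An unsubstituted phenyl would separate these two, and 2-chlorophenyl or 2-aminophenyl would show whether other groups on that ring keep, lose or extend the step.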